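Swapping Methoxy for Fluoro on a Low-Permeability Compound

The source may hold more compounds than are shown below. What is called first, only, known or untested is meant among the compounds shown, and "the series" means these compounds.

Among the compounds with values here, in an ADME assay for permeability, using PAMPA, at pH 7.4 (on this read-out higher numbers stand for higher permeability and lower numbers for lower permeability), compound 3 `COc1ccc2[nH]c(C)c(Br)c(=O)c2c1` gives 16.7 10^-6 cm/s, the lowest of the three numbers so far. Compound 2 `Cc1[nH]c2ccccc2c(=O)c1/C=C/c1cccc([N+](=O)[O-])c1` gives 602 10^-6 cm/s, and compound 1 `Cc1nc2ccccc2c(OCc2ccccc2)c1Br` gives 794 10^-6 cm/s. The gaps from each of these to compound 3 lie well beyond the usual scatter of repeated measurements.

Compound 4 `Cc1[nH]c2ccc(F)cc2c(=O)c1Br` has not yet been measured. It has fluoro in place of methoxy on an aromatic carbon of compound 3: fluoro in place of methoxy on an aromatic carbon.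

Within the data shown here, no two measured compounds differ in just one place, so the data offer no direct precedent for this swap. The range from compound 3 at 16.7 10^-6 cm/s to compound 1 at 794 10^-6 cm/s shows that numbers in this small set can lie far apart, but those two compounds differ in more than one place and say little about a single substitution. A small change is therefore the cautious expectation. The estimated step is a 1.8-fold higher number from compound 3 to compound 4 (0.25 log units; within the scatter), a slight rise that is expected to stay within the scatter or close to it. In this assay, compound 4 is expected to give about 30 10^-6 cm/s, with an estimated range from 10 10^-6 cm/s to 100 10^-6 cm/s.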

Compound 4, apparent permeability: 18.3 10^-6 cm/s
Compound 4: the middle estimate sits 1.6-fold (0.21 log units) above what was measured, and the stated range covers the measured number.
By their numbers in this assay, from the lowest: compounds 3 and 4 (each within the scatter of the next); then compounds 2 and 1 (each within the scatter of the next).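

In this assay the swap gives a 1.1-fold higher number from compound 3 to compound 4 (0.04 log units; within the scatter) and so, on this aromatic carbon of the shared core, fluoro in place of methoxy leaves two numbers that cannot be told apart. Within the data shown here, this is the first single-place comparison in the set; the wide spread among the earlier compounds came only from compounds that differ in more than one place, and it gave no view of what one group does at this position. Here, methoxy with its two heavy atoms and one hydrogen-bond acceptor and fluoro with its one heavy atom and no hydrogen-bond acceptor give the same reading within the scatter, and no measurement at hand explains this match.

Open, on these data alone, is whether a quite different group at this position, such as an amine, a carboxylic acid or a longer chain like butoxy, would shift the number beyond the scatter. Also open, as far as these compounds go, is whether the same swap would give so small a step on a core carrying other groups, such as the core of compound 2.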